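A few compounds are considered here, and "the series" means these few. Any claim that something is new, unique, unknown or untested is made for them only; others in the source may bear on it.

Two members of the series have been run in a functional assay on the whole organism (strain Wistar albino) for inhibition, with Rattus norvegicus as the target, read by paw edema, with stated times of 30 min and 3 h, at a dose of 50 mg/kg by the oral route; a lower number here means less inhibition, a higher number more inhibition at the dose given (going by the name of the read-out). Compound 1 `NS(=O)(=O)c1ccc2nc(-n3nc(C(F)(F)F)cc3-c3ccc(Cl)cc3)sc2c1` gives 61%. Compound 2 `NS(=O)(=O)c1ccc2nc(-n3nc(C(F)(F)F)cc3-c3ccccc3)sc2c1` gives 54%, the lower of the two numbers, and the gap to compound 1 lies within the scatter. Among the compounds with values here, the one measured step, a number 7 percentage points lower from compound 1 to compound 2 (within the scatter), is a hydrogen in place of chloro on an aromatic carbon, so the ring itself is unchanged. Compound 3 `NS(=O)(=O)c1ccc2nc(-n3nc(C(F)(F)F)cc3-c3cccs3)sc2c1` differs from compound 2 by thiophen-2-yl in place of phenyl on an aromatic carbon. Within the data shown here, no measured step exchanges the phenyl, so no movement beyond the scatter is expected in this assay. Compound 3 is estimated at 52% (range 38% to 66%), an expected step of a number 2 percentage points lower from compound 2 to compound 3 (within the scatter).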

Compound 3, a percentage reported as inhibition, in the whole organism at one dose (the size of the read-out at that dose, not a potency): 49%
Beside the measured number, compound 3's estimate is 3 percentage points above it; measured number inside the range.
By their numbers in this assay, from the lowest: compounds 3, 2 and 1 (each within the scatter of the next, the first and the last beyond it).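

In this assay, thiophen-2-yl in place of phenyl gives a number 5 percentage points lower from compound 2 to compound 3 (within the scatter), so at this position a five-membered aromatic ring with sulfur reads the same as phenyl. Set against 4-chlorophenyl, the same ring gives a number 12 percentage points lower from compound 1 to compound 3 (beyond the scatter), the first step in the series beyond the scatter, though a modest one. Nothing measured on these compounds speaks to the reason for either step. Still open, on these data alone, is how a chloro on the thiophen-2-yl would read. Also open, as far as these compounds go, is how an amine or a carboxylic acid on the aromatic ring at this position would read.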